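The source may report more compounds than this note shows. Statements on the series, on what has been measured and on what is new or still open speak of the compounds shown alone.

Of the compounds shown here, two have been measured in a functional assay for agonist activity at growth hormone secretagogue receptor type 1 (Homo sapiens), read by FLIPR; on this read-out lower numbers stand for smaller maximal responses and higher numbers for larger maximal responses. Compound 1, `C[C@@H]1CN(c2cccc(NS(=O)(=O)c3ccc(-c4ccccn4)s3)c2)C[C@H](C)N1`, gives 0.8 in this assay. Compound 2, `COc1ccc(F)c(-c2ccc(S(=O)(=O)Nc3cc(N4C[C@@H](C)N[C@@H](C)C4)ccc3OC)cc2)c1`, gives 1.2 in this assay, the higher of the two numbers, and the gap between compound 1 and compound 2 is beyond the usual scatter of repeated measurements. Compound 3, `COc1ccc(N2C[C@@H](C)N[C@@H](C)C2)cc1NS(=O)(=O)c1ccc(-c2cc(Cl)ccc2F)cc1`, has not yet been measured. It differs from compound 2 in one place: chloro in place of methoxy on an aromatic carbon. For the measured compounds named here, no step between two measured compounds shows what a change of this kind does to the maximal response, so the expectation rests on compound 2 alone. The change is small in size, and a step of a number 0.10 lower from compound 2 to compound 3 (within the scatter) is expected, that is, none beyond the scatter, with its direction uncertain. Compound 3 is therefore estimated to reach 1.1 in this assay, most likely between 0.8 and 1.4.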

Compound 3, intrinsic activity: the largest response reached, as a fraction of the reference agonist's: 1
For compound 3 the middle estimate is 0.10 above the measured one; measured number inside the range.
By their numbers in this assay, from the lowest: compound 1; then compound 3; then compound 2.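

In this assay, putting chloro in place of methoxy on this aromatic carbon, para to a fluoro group, gives a modest step of a number 0.20 lower from compound 2 to compound 3 (beyond the scatter). For the compounds shown here, this is the first sign that the maximal response is sensitive to which group sits at this position, even when the exchange is as small as turning 2-fluoro-5-methoxyphenyl into 5-chloro-2-fluorophenyl. Nothing available explains why the response moves in this direction.

This single pair cannot separate the effect of losing methoxy from the effect of gaining chloro, so it remains unclear which of the two drives the step. As far as these compounds go, how a methyl group, a nitrile or an amine on this same carbon would compare with chloro and methoxy also remains open.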